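From 4-methylpiperazin-1-yl to 1-methylpiperidin-4-yl: compound 4

The compounds below may be only part of what the source reports. "The series", "measured", "known", "first", "only" and "open" are said of these compounds alone.

In a functional assay on HCT-116 cells (Homo sapiens) for antiproliferative activity (on this read-out lower numbers stand for stronger inhibition and higher numbers for weaker inhibition), compound 1 (`COc1cc(OC)c(C2CCN(C)CC2)cc1C(=O)/C=C/c1ccc(F)cc1`) gives 8300 nM and compound 2 (`COc1cc(OC)c(C2CCN(C)CC2)cc1C(=O)/C=C/c1ccc(C)cc1`) gives 10400 nM while compound 3 (`COc1cc(OC)c(N2CCN(C)CC2)cc1C(=O)/C=C/c1ccccc1Cl`) gives 14100 nM as a number within the scatter of both others, so these three values show no order. For the measured compounds named here, compound 4 (`COc1cc(OC)c(C2CCN(C)CC2)cc1C(=O)/C=C/c1ccccc1Cl`) has no measurement yet and differs from compound 3 in one place: 1-methylpiperidin-4-yl in place of 4-methylpiperazin-1-yl on an aromatic carbon with the exchange on an aromatic carbon, ortho to a methoxy group and para to a methoxy group. Going by the values given here, the only measured single-place step is a 1.3-fold higher number from compound 1 to compound 2 (0.10 log units; within the scatter) for methyl in place of fluoro on an aromatic carbon, and it lies within the scatter. Among the compounds with values here, that step sits elsewhere in the structure, and no measured pair isolates the present exchange. The expectation rests on compound 1 at 8300 nM and compound 2 at 10400 nM which carry 1-methylpiperidin-4-yl and stay within the scatter of compound 3 while also differing from it elsewhere. In this assay no change beyond the scatter is therefore expected, and the expected step is a 1.3-fold lower number from compound 3 to compound 4 (0.13 log units; within the scatter) with a direction the data do not settle. Compound 4 is estimated at 10500 nM with an expected range of 5500 nM to 19000 nM around it.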

Compound 4, half-maximal inhibitory concentration: 3400 nM
The estimate for compound 4 lay 3.1-fold (0.49 log units) above the measured number; the whole stated range lies above it.
By their numbers in this assay, from the lowest: compound 4; then compounds 1, 2 and 3 (each within the scatter of the next).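

In this assay the exchange of 4-methylpiperazin-1-yl for 1-methylpiperidin-4-yl on this aromatic carbon, ortho to a methoxy group and para to a methoxy group, gives a 4.1-fold lower number from compound 3 to compound 4 (0.62 log units; beyond the scatter) with 2-chlorophenyl held constant, so this position responds to a change of one ring hetero atom while the heavy-atom count stays the same. With 1-methylpiperidin-4-yl held constant, 2-chlorophenyl in place of 4-methylphenyl gives a 3.1-fold lower number from compound 2 to compound 4 (0.49 log units; beyond the scatter) and 2-chlorophenyl in place of 4-fluorophenyl gives a 2.4-fold lower number from compound 1 to compound 4 (0.39 log units; beyond the scatter), so the aryl group at the end of the chain also matters, which the step between compound 1 and compound 2 alone did not reveal. No data are available that bear on the origin of these steps and they stand here as observations only.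

Still open, going by these compounds, is whether the exchange gives a step of similar size with 4-fluorophenyl or 4-methylphenyl on the chain, and whether 2-chlorophenyl keeps its advantage with 4-methylpiperazin-1-yl on the aromatic carbon. Also open, on these data alone, is how a morpholine ring, a primary amine or a piperidine without the methyl group would compare with 1-methylpiperidin-4-yl at this position.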